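Three stereoisomers tolerated at the limit; a fourth expected alike

This account rests on a few compounds, and the source may have more. Where it says the series, first, only, none or still open, it means among the compounds named here.

Compound 1 `Nc1nc2c(ncn2/C=C2\C[C@@H]2[C@H](O)CO)c(=O)[nH]1` — in an ADME assay on HFF cells (Homo sapiens) for cytotoxicity, read by neutral red uptake (a lower number here means that less compound is tolerated, a higher number that more compound is tolerated), compound 1 gives > 300000 nM, a limit of the assay.
Compound 2 `Nc1nc2c(ncn2/C=C2\C[C@@H]2[C@@H](O)CO)c(=O)[nH]1` — in this assay compound 2 gives > 300000 nM, a limit of the assay.
Compound 3 `Nc1nc2c(ncn2/C=C2/C[C@@H]2[C@@H](O)CO)c(=O)[nH]1` — in this assay compound 3 gives > 300000 nM, a limit of the assay.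

Compound 3 stands where both other compounds stand: none of the three gives a number, only a limit, so none can be ranked against another in this assay. The step to compound 4 `Nc1nc2c(ncn2/C=C2/C[C@H]2[C@H](O)CO)c(=O)[nH]1` is a change in configuration alone: the two compounds have the same atoms and bonds and differ only in configuration as drawn: 2 of 3 stereo elements differ; a stereocentre at a saturated ring carbon is drawn S in compound 3 and R in compound 4; a stereocentre at a saturated chain carbon is drawn R in compound 3 and S in compound 4. The measured steps that resemble it are also pure changes in configuration, and each is a step that the two limits leave unreadable from compound 1 to compound 2, a step that the two limits leave unreadable from compound 1 to compound 3 and a step that the two limits leave unreadable from compound 2 to compound 3, so they give no readable size in either direction because of the limit of > 300000 nM in this assay, at which 3 of the 3 values shown sit, (the fact that compounds 1 and 2 differ only in the configuration as drawn), the fact that compounds 1 and 3 differ only in the configuration as drawn and the fact that compounds 2 and 3 differ only in the configuration as drawn show only that every isomer sat at the same limit. For the configurational step to compound 4 no shift beyond the scatter is therefore expected, and the assay is most likely to report a limit again; the estimated step is a step that the limit leaves unreadable from compound 3 to compound 4. Compound 4 is estimated at 400000 nM, within 200000 nM to 1000000 nM.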

Compound 4, half-maximal cytotoxic concentration: > 300000 nM
Compound 4 ended at the assay's limit; the forecaster's own chance of this, stated with the estimate: 85%; the middle value does not contradict the limit.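

Within the data shown here, compound 4 gives only a limit of the assay, as do compounds 1, 2 and 3, and no step from any of these three to compound 4 can be read. The compounds shown leave open whether configuration affects tolerance in this assay beyond that limit.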